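Benzyl ester in place of amide on a purine glycinamide

A few compounds are considered here, and "the series" means these few. Any claim that something is new, unique, unknown or untested is made for them only; others in the source may bear on it.

Measured so far:
compound 1, `O=C(OCc1ccccc1)[C@@H]1CCCN1C(=O)CN(c1nc(Cl)nc2[nH]cnc12)C1CC1`: 31.1%
compound 2, `NC(=O)CC[C@H](NC(=O)CN(c1ncnc2c1ncn2C1CCCCO1)C1CC1)C(=O)OCc1ccccc1`: 10.7%
compound 3, `NC(=O)CC[C@H](NC(=O)CN(c1nc(Cl)nc2[nH]cnc12)C1CC1)C(=O)O`: 11.4%

In a functional assay on the whole organism (Tail, strain ICR) with Mus musculus as the target, in the tail flick test, with a stated time of 150 min, at a dose of 25 umol/kg by the oral route (a lower number here means a weaker effect, a higher number a stronger effect of the compound at the dose given), compound 2 gives the lowest of the three numbers. Its nearest neighbour is compound 3, which in this assay gives a number within the scatter of it, so the two cannot be ordered. Compound 1 stands beyond the scatter above both. Among the compounds with values here, no single-point step between measured compounds is known here.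

Compound 4, `O=C(CN(c1ncnc2c1ncn2C1CCCCO1)C1CC1)N[C@@H](CCC(=O)OCc1ccccc1)C(=O)OCc1ccccc1`, differs from compound 2 in one place: benzyloxy in place of amino on a carbonyl carbon. Within the data shown here, with no comparable step measured, the size of this change is open; a step of a number 5.3 percentage points higher from compound 2 to compound 4 (within the scatter) is expected, small and not clearly beyond the scatter. For compound 4 a read-out of 16% is estimated, with a range from 5% to 35%.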

Compound 4, a percentage reported as activity, at one dose (the size of the read-out at that dose, not a potency): 14.1%
Compound 4: the middle estimate sits 1.9 percentage points above what was measured; the range from low to high includes it.
By their numbers in this assay, from the lowest: compounds 2, 3 and 4 (each within the scatter of the next); then compound 1.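

In this assay, benzyloxy in place of amino on a carbonyl carbon gives a number 3.4 percentage points higher from compound 2 to compound 4 (within the scatter). This first single-place comparison shows that the read-out does not separate carbamoyl from benzyloxycarbonyl on this side chain, even though the entering group brings 8 heavy atoms and a six-membered aromatic ring. Nothing available gives a reason for this result.

On these data alone, what a carboxylic acid or a methyl ester would give on this carbonyl carbon remains open. So does whether the two groups would still read alike at another dose.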